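Chain Length on an Imidazole Nitrogen and Cell Growth Inhibition

The source may hold more compounds than are shown below. What is called first, only, known or untested is meant among the compounds shown, and "the series" means these compounds.

Of the compounds shown here, three sharing one core have been measured: compound 1 `Cn1ccnc1/C=C/C(=O)/C=C/c1coc2ccccc2c1=O`, compound 2 `CCn1ccnc1/C=C/C(=O)/C=C/c1coc2ccccc2c1=O` and compound 3 `CCCCn1ccnc1/C=C/C(=O)/C=C/c1coc2ccccc2c1=O`. A fourth, compound 4 `CCCCCn1ccnc1/C=C/C(=O)/C=C/c1coc2ccccc2c1=O`, is not yet measured. In a functional assay on DU-145 cells (Homo sapiens) for inhibition, read by WST assay, with a stated time of 3 days (a higher number here means a weaker inhibitor, a lower number a stronger inhibitor), compound 1 gives 4500 nM, compound 2 gives 3000 nM and compound 3 gives 4300 nM. The steps are a 1.5-fold lower number from compound 1 to compound 2 (0.18 log units; within the scatter), a 1.0-fold lower number from compound 1 to compound 3 (0.02 log units; within the scatter) and a 1.4-fold higher number from compound 2 to compound 3 (0.16 log units; within the scatter), so none of the three can be set apart from the others.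

Compound 2 arises from compound 1 by methyl in place of hydrogen on a saturated chain carbon bound to an aromatic nitrogen. Compound 4 arises from compound 3 by methyl in place of hydrogen on a saturated chain carbon, four bonds along the chain from an aromatic nitrogen. This is the same kind of change, but not the same: in the first it sits bound to an aromatic nitrogen, in the second four bonds along the chain from an aromatic nitrogen. The cores of compound 1 and compound 3 themselves differ by propyl in place of hydrogen on a saturated chain carbon bound to an aromatic nitrogen.

Because a 1.5-fold lower number from compound 1 to compound 2 (0.18 log units; within the scatter) stayed within the scatter, and because a 1.0-fold lower number from compound 1 to compound 3 (0.02 log units; within the scatter) did as well, a step of a 1.1-fold lower number from compound 3 to compound 4 (0.03 log units; within the scatter) is expected for compound 4. Compound 4 is therefore estimated at 4000 nM, between 2000 nM and 8000 nM.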

Compound 4, half-maximal inhibitory concentration: 2700 nM
For compound 4 the middle estimate is 1.5-fold (0.17 log units) above the measured one; low and high end bracket the measured number.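

In this assay, methyl in place of hydrogen gives a 1.6-fold lower number from compound 3 to compound 4 (0.20 log units; within the scatter), and setting this beside the earlier step shows no difference: the same change on two cores in this assay, a 1.5-fold lower number (0.18 log units; within the scatter) from compound 1 to compound 2 and a 1.6-fold lower number (0.20 log units; within the scatter) from compound 3 to compound 4, 1.1-fold (0.03 log units) apart, within the scatter of two such steps. Longer pieces tell the same story, with propyl giving a 1.1-fold lower number from compound 2 to compound 4 (0.05 log units; within the scatter) and butyl giving a 1.7-fold lower number from compound 1 to compound 4 (0.22 log units; within the scatter), and the propyl step matches its earlier counterpart: the same change on two cores in this assay, a 1.0-fold lower number (0.02 log units; within the scatter) from compound 1 to compound 3 and a 1.1-fold lower number (0.05 log units; within the scatter) from compound 2 to compound 4, 1.1-fold (0.03 log units) apart, within the scatter of two such steps. The change therefore carries from one core to another in a limited sense: its step stays within the scatter on both cores, but this does not show that the change has any real effect to carry, nor that the agreement would hold on cores outside this series.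

The compounds shown leave open whether a much longer chain, or an amine or a carboxylic acid on the chain, would move the number beyond the scatter. They also leave open whether a step of that size would carry from one core to another as these small steps do.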